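A few compounds are considered here, and "the series" means these few. Any claim that something is new, unique, unknown or untested is made for them only; others in the source may bear on it.

Compound 1 `O=C(NCc1ccc(S(=O)(=O)c2ccccc2)cc1)c1cc2ncccc2s1` — 1.6%
Compound 2 `O=C(NCc1ccc(S(=O)(=O)c2ccccc2)cc1)c1nc2cnccc2[nH]1` — 7.3%
Compound 3 `O=C(NCc1ccc(S(=O)(=O)c2ccccc2)cc1)c1cnc2nccn2c1` — 30%

Among the measured compounds shown here, of the three compounds measured so far in an ADME assay on microsomes from liver (Mus musculus) for metabolic stability, read by LC-MS, with a stated time of 30 min, tested at 1 uM (on this read-out lower numbers stand for a less stable compound and higher numbers for a more stable compound), compound 3 stands highest. Its nearest neighbour is compound 2, and the step of a number 22.7 percentage points higher from compound 2 to compound 3 (beyond the scatter) lies beyond the scatter; the step of a number 28.4 percentage points higher from compound 1 to compound 3 (beyond the scatter) is larger still. Between compound 1 and compound 2 the step of a number 5.7 percentage points higher from compound 1 to compound 2 (within the scatter) stays within the scatter, so those two cannot be ordered.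

Compound 4 `O=C(NCc1ccc(S(=O)(=O)c2ccccc2)cc1)c1cc2cnccc2[nH]1` differs from compound 3 only at the carbonyl carbon: a group of 9 heavy atoms (7 carbon, 2 nitrogen; one five-membered aromatic ring with 1 hetero atom, one six-membered aromatic ring with 1 hetero atom) in place of a group of 9 heavy atoms (6 carbon, 3 nitrogen; one five-membered aromatic ring with 2 hetero atoms, one six-membered aromatic ring with 2 hetero atoms), on a carbonyl carbon. The group that enters resembles the groups of compound 1 and compound 2 in that each ring carries fewer hetero atoms than in compound 3, and it carries one hydrogen-bond donor as compound 2 does. The two steps that bear on this change, a number 28.4 percentage points higher from compound 1 to compound 3 (beyond the scatter) and a number 22.7 percentage points higher from compound 2 to compound 3 (beyond the scatter), both ran upward when the group of compound 3 entered; moving away from that group is therefore expected to run the other way, with a step of modest size beyond the scatter.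

For compound 4 the expected step is a number 22 percentage points lower from compound 3 to compound 4 (beyond the scatter), bringing it back toward the values of compound 1 and compound 2. The estimated result for compound 4 in this assay is 8%, with a likely range from 2% to 20%.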

Compound 4, percent of the compound remaining: 54%
Beside the measured number, compound 4's estimate is 46 percentage points below it, and the stated range ends below it.
By their numbers in this assay, from the lowest: compounds 1 and 2 (each within the scatter of the next); then compound 3; then compound 4.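

In this assay, among the compounds shown here, the position on the carbonyl carbon proves more sensitive to the exact arrangement of the fused pair of rings than the earlier compounds showed, and a greater number of hetero atoms in the rings does not give the highest number: the group with fewer of them stands higher, with a number 24 percentage points higher from compound 3 to compound 4 (beyond the scatter) as the step. Counting ring hetero atoms does not order these compounds either, since the group of compound 1 has the same count in each ring as the group that enters, and yet the change shows a number 52.4 percentage points higher from compound 1 to compound 4 (beyond the scatter) as a large step, while the other large step is a number 46.7 percentage points higher from compound 2 to compound 4 (beyond the scatter) and involves a group with the same ring sizes. Nothing measured here accounts for any of these steps, so the rise of compound 4 remains an observation without an explanation.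

The compounds shown leave open whether the number holds once the group that enters carries a further substituent, such as a methyl group, a fluorine atom or an amine. They also leave open how much of the step depends on where the ring nitrogen stands within that group, as opposed to the group as a whole.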